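Triazole ether series: cytotoxicity notes ahead of compound 4

The source may hold more compounds than are shown below. What is called first, only, known or untested is meant among the compounds shown, and "the series" means these compounds.

Measured so far in a toxicity assay on RAW264.7 cells (Mus musculus) for cytotoxicity, read by MTT assay, with a stated time of 24 h; a lower number here means a stronger inhibitor, a higher number a weaker inhibitor:
Compound 1 `C=C[C@@](C)(/C=C/c1ccc(OCc2cn(-c3ccccc3)nn2)cc1)CCC=C(C)C` gives 172000 nM.
Compound 2 `C=C[C@@](C)(/C=C/c1ccc(OCc2cn(-c3ccc(Cl)cc3)nn2)cc1)CCC=C(C)C` gives 47600 nM.
Compound 3 `C=C[C@@](C)(/C=C/c1ccc(OCc2cn(Cc3ccc(F)cc3)nn2)cc1)CCC=C(C)C` gives 157000 nM.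

Compound 2 holds the lowest number of the three, and both steps to it lie beyond the scatter: a 3.6-fold lower number from compound 1 to compound 2 (0.56 log units; beyond the scatter) and, going the other way, a 3.3-fold higher number from compound 2 to compound 3 (0.52 log units; beyond the scatter). Compound 4 `C=C[C@@](C)(/C=C/c1ccc(OCc2cn(Cc3ccc(C)cc3)nn2)cc1)CCC=C(C)C` differs from compound 2 thus: 4-methylbenzyl in place of 4-chlorophenyl on an aromatic nitrogen.

Among the compounds with values here, two measured steps bear on this. The benzyl-for-aryl swap a 3.3-fold higher number from compound 2 to compound 3 (0.52 log units; beyond the scatter) gave a modest rise, while a 1.1-fold lower number from compound 1 to compound 3 (0.04 log units; within the scatter) stayed within the scatter, so the benzyl compounds sit near compound 1. A modest rise is therefore expected for compound 4, roughly a 3.2-fold higher number from compound 2 to compound 4 (0.50 log units; beyond the scatter). Compound 4 is estimated at 150000 nM, with a range of 60000 nM to 350000 nM.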

Compound 4, half-maximal inhibitory concentration: 371000 nM
Compound 4: the middle estimate sits 2.5-fold (0.39 log units) below what was measured; the measured number lies above the stated range.
By their numbers in this assay, from the lowest: compound 2; then compounds 3 and 1 (each within the scatter of the next); then compound 4.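

In this assay, the substituent on the benzyl ring now counts: methyl in place of fluoro gives a 2.4-fold higher number from compound 3 to compound 4 (0.37 log units; beyond the scatter), although 4-fluorobenzyl in place of phenyl had stayed within the scatter. 4-Methylbenzyl on the aromatic nitrogen also separates from phenyl, with a 2.2-fold higher number from compound 1 to compound 4 (0.33 log units; beyond the scatter), and in place of 4-chlorophenyl it gives a 7.8-fold higher number from compound 2 to compound 4 (0.89 log units; beyond the scatter). No available evidence accounts for these steps.

Still open, from the compounds shown here alone, is whether 4-chlorobenzyl would match the 4-chlorophenyl number or stay with the other benzyl compounds. Going by these compounds, an amine or a carboxylic acid on that ring also remains untested in these notes.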